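A few compounds are considered here, and "the series" means these few. Any claim that something is new, unique, unknown or untested is made for them only; others in the source may bear on it.

Measured so far:
Compound 1, `C=CCc1cc(C(C)=O)c(O)cc1OCCCCC`, gives 60% in an assay on isolated protein for inhibition of leukotriene B4 receptor 1 (Homo sapiens), tested at 10 uM; on this read-out lower numbers stand for less inhibition and higher numbers for more inhibition at the one concentration tested (going by the name of the read-out).
Compound 2, `C=CCc1cc(C(C)=O)c(O)cc1OCCCCCCC`, gives 31%.
Compound 3, `C=CCc1cc(C(C)=O)c(O)cc1OCCCCO`, gives 48%.

Compound 3 stands second of the three numbers: compound 1 sits above it, since a number 12 percentage points lower from compound 1 to compound 3 (beyond the scatter), and compound 2 sits below it, since a number 17 percentage points higher from compound 2 to compound 3 (beyond the scatter). Compound 4 is `C=CCc1cc(C(C)=O)c(O)cc1OCCCCCC(=O)NO`. Its difference from compound 3 is (hydroxycarbamoyl)methyl in place of hydroxy on a saturated chain carbon, four bonds along the chain from an oxygen on an aromatic ring. Among the compounds with values here, two measured steps bear on this change. Lengthening the chain gave a number 29 percentage points lower from compound 1 to compound 2 (beyond the scatter), and exchanging a methyl for a hydroxy gave a number 12 percentage points lower from compound 1 to compound 3 (beyond the scatter). Compound 4 lengthens the chain while exchanging the hydroxy for a larger group, so a modest fall, or no step beyond the scatter, is expected; the estimated step is a number 8 percentage points lower from compound 3 to compound 4 (within the scatter). Compound 4 is therefore estimated at 40%, within a range from 15% to 65%.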

Compound 4, a percentage reported as inhibition, at one concentration (the size of the read-out at that concentration, not a potency): 85%
Beside the measured number, compound 4's estimate is 45 percentage points below it; the whole stated range lies below it.
By their numbers in this assay, from the lowest: compound 2; then compound 3; then compound 1; then compound 4.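

In this assay, this chain end proved able to carry a larger group with a higher number, not a lower one: (hydroxycarbamoyl)methyl in place of hydroxy gives a number 37 percentage points higher from compound 3 to compound 4 (beyond the scatter) on the shared core. Hydroxycarbamoyl also gives a number 25 percentage points higher from compound 1 to compound 4 (beyond the scatter) and a number 54 percentage points higher from compound 2 to compound 4 (beyond the scatter) against the plain chains, so compound 4 stands highest of the four, although lengthening the plain chain had lowered the number. Nothing available explains this rise.

The compounds shown leave open whether a carboxylic acid or a primary amide on the same chain would serve as well as hydroxycarbamoyl. They also leave open how the number changes when a shorter or longer chain carries that group.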